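Fluoro to trifluoromethyl on the outer ring, two cores

The source may report more compounds than this note shows. Statements on the series, on what has been measured and on what is new or still open speak of the compounds shown alone.

Compound 1 `Oc1cccc2[nH]c(-c3ccc(-c4ccc(-c5ccc(F)cc5)cc4)cc3)nc12` gives 2860 nM in a functional assay on Gurav cells (Homo sapiens) for inhibition, read by sulforhodamine B assay; a higher number here means a weaker inhibitor of growth, a lower number a stronger inhibitor of growth. Compound 2 `Oc1cccc2[nH]c(-c3ccc(-c4ccc(-c5ccc(C(F)(F)F)cc5)cc4)cc3)nc12` gives 3190 nM in this assay; the change trifluoromethyl in place of fluoro on an aromatic carbon produced a 1.1-fold higher number from compound 1 to compound 2 (0.05 log units; within the scatter). Compound 3 `Cc1ccc2[nH]c(-c3ccc(-c4ccc(-c5ccc(F)cc5)cc4)cc3)nc2c1` carries a different core and gives 16500 nM in this assay; the difference between the two cores is not broken down here, and the gap from compound 3 to the other two is beyond the scatter. Compound 4 `Cc1ccc2[nH]c(-c3ccc(-c4ccc(-c5ccc(C(F)(F)F)cc5)cc4)cc3)nc2c1` is unmeasured and differs from compound 3 by trifluoromethyl in place of fluoro on an aromatic carbon, the same change, at the same place, as from compound 1 to compound 2. Resting on a 1.1-fold higher number from compound 1 to compound 2 (0.05 log units; within the scatter), the step from compound 3 to compound 4 is expected to be a 1.1-fold higher number from compound 3 to compound 4 (0.04 log units; within the scatter). Compound 4 is estimated at 18000 nM in this assay, with 9000 nM to 36000 nM as the likely range.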

Compound 4, concentration for 50% growth inhibition: 12000 nM
Estimate against measurement, compound 4: 1.5-fold (0.18 log units) above, within the range that was stated.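

In this assay the change from fluoro to trifluoromethyl behaves alike on both cores: the same change on two cores in this assay, a 1.1-fold higher number (0.05 log units; within the scatter) from compound 1 to compound 2 and a 1.4-fold lower number (0.14 log units; within the scatter) from compound 3 to compound 4, 1.5-fold (0.19 log units) apart, within the scatter of two such steps

On the second core it gives a 1.4-fold lower number from compound 3 to compound 4 (0.14 log units; within the scatter), whereas with trifluoromethyl held, the change of core gives a 3.8-fold higher number from compound 2 to compound 4 (0.58 log units; beyond the scatter), so in these four compounds the core moves the number and this change does not. Both steps of the change lie within the scatter, so the pair shows only that a null result carried across two cores, not that a change with a real effect would carry across, or that the same holds on any other core.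

Open, from the compounds shown here alone, is whether an amine or a carboxylic acid in place of fluoro would move the number on either core. Also open, going by these compounds, is how a core bearing both hydroxy and methyl would read.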